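A few compounds are considered here, and "the series" means these few. Any claim that something is new, unique, unknown or untested is made for them only; others in the source may bear on it.

Series in a functional assay for inhibition of sodium/hydrogen exchanger (Oryctolagus cuniculus); on this read-out higher numbers stand for weaker inhibition and lower numbers for stronger inhibition:

compound 1 `CS(=O)(=O)c1cc(C(=O)N=C(N)N)c(Cl)cc1Oc1cccnc1` — 52 nM
compound 2 `CS(=O)(=O)c1cc(C(=O)N=C(N)N)ccc1Oc1cccnc1` — 76 nM
compound 3 `Cc1cc(Oc2cccnc2)c(S(C)(=O)=O)cc1C(=O)N=C(N)N` — 8.8 nM

Compound 2 gives the highest number of the three in this assay; compound 1 lies within the scatter of it, as a 1.5-fold higher number from compound 1 to compound 2 (0.16 log units; within the scatter) shows, while compound 3 lies well apart, as an 8.6-fold lower number from compound 2 to compound 3 (0.94 log units; beyond the scatter) shows.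

Compound 4 `CS(=O)(=O)c1cc(C(=O)N=C(N)N)ccc1Oc1cncc(Cl)c1` has not been measured. It differs from compound 2 by chloro in place of hydrogen on an aromatic carbon — the substituent enters the pyridin-3-yl part, on a carbon two atoms from the ring nitrogen, not the shared core.

For the measured compounds named here, none of the measured steps touches the pyridin-3-yl part. The closest analogy is the chloro step on the core, a 1.5-fold higher number from compound 1 to compound 2 (0.16 log units; within the scatter), which stayed within the scatter; the methyl steps a 5.9-fold lower number from compound 1 to compound 3 (0.77 log units; beyond the scatter) and an 8.6-fold lower number from compound 2 to compound 3 (0.94 log units; beyond the scatter) concern a different group at a different place and bear only loosely on this change. No shift beyond the scatter is therefore expected in this assay; the step from compound 2 to compound 4 is estimated at a 1.3-fold lower number from compound 2 to compound 4 (0.10 log units; within the scatter).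

Compound 4 is expected to give about 60 nM in this assay, within a range of 20 nM to 200 nM.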

Compound 4, half-maximal inhibitory concentration: 75 nM
Compound 4: the middle estimate sits 1.3-fold (0.10 log units) below what was measured; the range from low to high includes it.
By their numbers in this assay, from the lowest: compound 3; then compounds 1, 4 and 2 (each within the scatter of the next).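

Chloro on the pyridin-3-yl part, on the carbon two atoms from the ring nitrogen, leaves the number in this assay essentially unchanged (a 1.0-fold lower number from compound 2 to compound 4 (0.01 log units; within the scatter)). For the compounds shown here, this is the first measured step outside the shared core, and it shows that 5-chloropyridin-3-yl can stand in place of pyridin-3-yl with no shift beyond the scatter on the core of compound 2. Nothing at hand gives a reason for this flat step.

As far as these compounds go, whether this carbon stays as flat with an amine, a methoxy group or a nitrile in place of chloro remains open. Also open, from the compounds shown here alone, is whether the 5-chloropyridin-3-yl group behaves the same on the core of compound 3, where the methyl step (an 8.6-fold lower number from compound 2 to compound 3 (0.94 log units; beyond the scatter)) went beyond the scatter.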